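A few compounds are considered here, and "the series" means these few. Any claim that something is new, unique, unknown or untested is made for them only; others in the source may bear on it.

Measured compounds:
Compound 1 `COc1cccc(-c2cc(-c3cc4cc(OC)ccc4[nH]3)no2)c1` — in a functional assay on COLO 320 cells (Homo sapiens) for cytotoxicity, read by WST assay, with a stated time of 72 h (a lower number here means a stronger inhibitor, a higher number a weaker inhibitor), compound 1 gives > 100000 nM, which is a limit of the assay rather than a number.
Compound 2 `COc1ccc2[nH]c(-c3cc(-c4cccc(F)c4)on3)cc2c1` — compound 2 gives > 100000 nM, again a limit.
Compound 3 `COc1cccc(-c2cc(-c3cc4ccccc4n3C)on2)c1` — compound 3 gives > 100000 nM, again a limit.

Compound 1 therefore has no measured number in this assay, only a limit. The same holds for every compound here: the limit of > 100000 nM in this assay, at which 3 of the 3 values shown sit. For the measured compounds named here, the one step between measured compounds that differ in a single place, a step that the two limits leave unreadable from compound 1 to compound 2, is unreadable for that reason, so no measured step gives a size that can be carried over.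

Compound 4 `COc1cccc(-c2cc(-c3cc4ccccc4[nH]3)no2)c1` is compound 1 with hydrogen in place of methoxy on an aromatic carbon. Going by the values given here, no measured step bears on this change, and the two steps that do exist both end at the limit. With nothing to point the other way, compound 4 is expected to sit where compound 1 sits, at the limit, with an expected step that the limit leaves unreadable from compound 1 to compound 4. The estimate for compound 4 is 150000 nM, with a range from 50000 nM to 500000 nM.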

Compound 4, half-maximal inhibitory concentration: > 100000 nM
Compound 4: no number, only a limit (the forecaster's own chance of this, stated with the estimate: 80%); the middle value does not contradict the limit.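

No size can be read for the change from compound 1 to compound 4, because both values are limits and not numbers: the limit of > 100000 nM in this assay, at which 4 of the 4 values shown sit. The compounds shown leave open whether any of these changes to the core of compound 1 alters cytotoxicity at all, and by how much.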